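This account rests on a few compounds, and the source may have more. Where it says the series, first, only, none or still open, it means among the compounds named here.

Measured in an ADME assay on BJ cells (Homo sapiens) for cytotoxicity, read by MTT assay, with a stated time of 72 h; a higher number here means a weaker inhibitor, a lower number a stronger inhibitor:

Compound 1 `COc1ccc(CNc2ncnc3c2ncn3C2CCCCO2)c(OC)c1`: > 25000 nM
Compound 2 `COc1ccc(CNc2ncnc3c2ncn3C2CCCO2)cc1`: > 100000 nM

Compound 2 stands at > 100000 nM, which is a limit and not a number. Compound 1 also shows only a limit, > 25000 nM.

Compound 3 `COc1ccc(CNc2ncnc3c2ncn3C2CCCO2)c(OC)c1` differs from compound 2 by methoxy in place of hydrogen on an aromatic carbon, ortho to a large group. Among the measured compounds shown here, no measured pair shows what this change does. A shift beyond the usual scatter in this assay is not expected, in either direction. The expected step of a number no higher from compound 2 to compound 3 (the limit leaves the size open) is therefore small. For compound 3 the estimate is 100000 nM, expected to fall between 30000 nM and 200000 nM.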

Compound 3, half-maximal inhibitory concentration: > 100000 nM
Compound 3 gave a limit, no number; the forecaster's own chance of this, stated with the estimate: 85%; the middle value lies on the limit itself.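

No step to compound 3 can be read from compound 2 or compound 1, because each of the three shows only a limit: the limit of > 100000 nM in this assay, at which 2 of the 3 values shown sit.

The compounds shown leave open how far methoxy in place of hydrogen, or oxolan-2-yl in place of oxan-2-yl, shifts the true value in this assay.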